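This account rests on a few compounds, and the source may have more. Where it says the series, first, only, none or still open, it means among the compounds named here.

Going by the values given here, compound 2 `Cc1ccccc1C(=O)NCc1ccc(CNS(=O)(=O)c2ccccc2Cl)cc1` stands at the higher end of the two numbers so far: in an assay on MDA-MB-231 cells for displacement of a labelled ligand from C-X-C chemokine receptor type 4 (Homo sapiens), read by fluorescence and microscopy, with stated times of 10 min and 30 min (on this read-out lower numbers stand for an effect already at smaller amounts and higher numbers for an effect only at larger amounts of compound), compound 2 gives 1000 nM, while compound 1 `Cc1ccccc1C(=O)NCc1ccc(CNS(=O)(=O)c2ccc(F)cc2)cc1` gives 10 nM. Among the compounds with values here, the single step with a measured pair, a 100-fold higher number from compound 1 to compound 2 (2.00 log units; beyond the scatter), alters the same position, the sulfonyl sulfur, and so bears directly on the next change. Compound 3 `Cc1ccccc1C(=O)NCc1ccc(CNS(=O)(=O)c2cccc3ccccc23)cc1` carries naphthalen-1-yl in place of 2-chlorophenyl on a sulfonyl sulfur. That earlier step shows this position to be sensitive, with a large move on one swap of the aryl group; the pair measured so far gives no pointer to which way a naphthalen-1-yl will go. For compound 3 the step of a 3.3-fold lower number from compound 2 to compound 3 (0.52 log units; beyond the scatter) is therefore expected to fall towards a lower number, but with wide uncertainty. Compound 3 is estimated at 300 nM, within a range of 30 nM to 3000 nM.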

Compound 3, effective concentration (reported as EC, without a stated level of effect): 100 nM
Compound 3: the middle estimate sits 3.0-fold (0.48 log units) above what was measured, within the range that was stated.
By their numbers in this assay, from the lowest: compound 1; then compound 3; then compound 2.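

In this assay, naphthalen-1-yl on the sulfonyl sulfur gives a 10-fold lower number from compound 2 to compound 3 (1.00 log units; beyond the scatter), so a second aromatic ring is compatible with a lower number than 2-chlorophenyl gives. The same group still gives a 10-fold higher number from compound 1 to compound 3 (1.00 log units; beyond the scatter), which leaves 4-fluorophenyl with the lowest number of the three. Ring count alone does not order these compounds, since compound 3, with two rings, falls between the single-ring compounds 1 and 2.

Still open, as far as these compounds go, is whether the gap between compound 1 and compound 2 follows the halogen or its place on the ring, which 4-chlorophenyl and 2-fluorophenyl would separate, and how naphthalen-2-yl or unsubstituted phenyl would compare. Nothing at hand accounts for the size or direction of these steps.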